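This account rests on a few compounds, and the source may have more. Where it says the series, first, only, none or still open, it means among the compounds named here.

Measured compounds in an assay on isolated protein for inhibition of Gonadotropin-releasing hormone receptor (Rattus norvegicus); on this read-out lower numbers stand for stronger inhibition and higher numbers for weaker inhibition:
compound 1 `CCn1c(SCc2cc([N+](=O)[O-])ccc2OC)nc2cc(NC(=O)NC(C)(C)C)ccc21` gives 170 nM
compound 2 `COc1ccc([N+](=O)[O-])cc1CSc1nc2cc(NC(=O)NC(C)(C)C)ccc2n1Cc1cccnc1` gives 150 nM

On the numbers shown, compound 2 stands alongside compound 1, and the step of a 1.1-fold lower number from compound 1 to compound 2 (0.05 log units; within the scatter) is within the scatter, so the two cannot be told apart in this assay. Within the data shown here, that step is the only measured change, and it sits on the saturated chain carbon bound to the aromatic nitrogen.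

Compound 3 `COc1ccc([N+](=O)[O-])cc1CSc1nc2cc(NC(=O)NC(C)(C)C)ccc2n1Cc1ccncc1` is not yet measured. It differs from compound 2 by pyridin-4-yl in place of pyridin-3-yl on a saturated chain carbon bound to an aromatic nitrogen. Among the measured compounds shown here, no measured pair compares pyridin-3-yl with pyridin-4-yl at this place. For the measured compounds named here, the one step that touches this carbon, a 1.1-fold lower number from compound 1 to compound 2 (0.05 log units; within the scatter), exchanged methyl for pyridin-3-yl and stayed within the scatter, which gives no sign that the group on this carbon moves the number much. On that basis the step expected for compound 3, no change at the digits printed from compound 2 to compound 3 (within the scatter), is none beyond the scatter in this assay. The estimate for compound 3 in this assay is 150 nM, with a range from 60 nM to 400 nM.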

Compound 3, half-maximal inhibitory concentration: 240 nM
For compound 3 the middle estimate is 1.6-fold (0.20 log units) below the measured one; the range from low to high includes it.
By their numbers in this assay, from the lowest: compounds 2, 1 and 3 (each within the scatter of the next).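

In this assay, pyridin-4-yl in place of pyridin-3-yl on the saturated chain carbon bound to the aromatic nitrogen gives a 1.6-fold higher number from compound 2 to compound 3 (0.20 log units; within the scatter), so this first direct comparison of the two pyridinyl groups does not separate them. Set against methyl at the same place, pyridin-4-yl gives a 1.4-fold higher number from compound 1 to compound 3 (0.15 log units; within the scatter), which means that methyl, pyridin-3-yl and pyridin-4-yl all stand within the scatter of one another, and none of the three exchanges at this place gives a step beyond it. No supporting measurement is available to explain the small differences among these values.

On these data alone, whether a group of a different kind at this place, such as a primary amine or a carboxylic acid carried on a longer chain, would give a step beyond the scatter remains open. As far as these compounds go, the rest of the structure is the same in all three compounds, so these readings apply only to this one place on this shared core, and whether they would hold with other groups elsewhere on it is also open.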